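The source may hold more compounds than are shown below. What is called first, only, known or untested is meant among the compounds shown, and "the series" means these compounds.

Measured in a functional assay on HCT-8 cells (Homo sapiens) for cytotoxicity, read by sulforhodamine B assay; on this read-out lower numbers stand for an effect already at smaller amounts and higher numbers for an effect only at larger amounts of compound:
- compound 1 `O=C1CC(c2ccccc2)Nc2ccccc21`: 0.013 ug/mL
- compound 2 `COc1cccc(C2CC(=O)c3ccccc3N2)c1`: 0.12 ug/mL

Of these two compounds, compound 2 carries the higher number, so it needs the larger amount for its effect. The account now turns to compound 3 `COc1cccc(C2CC(=O)c3cc(N4CCCC4)ccc3N2)c1`, which differs from compound 2 by pyrrolidin-1-yl in place of hydrogen on an aromatic carbon.

For the measured compounds named here, only one measured step bears on this change, and only indirectly: a 9.2-fold higher number from compound 1 to compound 2 (0.97 log units; beyond the scatter). That step swaps in methoxy, a different group, so it gives no direction for pyrrolidin-1-yl. Going by the values given here, no measured pair shows what any substituent does at the new place. The step does show how far a single substitution can move the number in this small set, and that size sets the width of the expectation.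

With no direction supported, no shift beyond the scatter is expected in this assay, though the uncertainty is wide. The expected step is a 1.2-fold lower number from compound 2 to compound 3 (0.08 log units; within the scatter). For compound 3 the estimated value is 0.1 ug/mL, with an expected range from 0.015 ug/mL to 0.7 ug/mL.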

Compound 3, concentration for half-maximal effect: 0.016 ug/mL
For compound 3 the middle estimate is 6.3-fold (0.80 log units) above the measured one, within the range that was stated.
By their numbers in this assay, from the lowest: compounds 1 and 3 (each within the scatter of the next); then compound 2.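

With a 7.5-fold lower number from compound 2 to compound 3 (0.88 log units; beyond the scatter) in this assay, this aromatic carbon of the shared core gives its first measured result: it accepts pyrrolidin-1-yl, a group of five heavy atoms, and the number falls rather than rises. The earlier step, a 9.2-fold higher number from compound 1 to compound 2 (0.97 log units; beyond the scatter), ran the other way for methoxy at a different place, so the set now holds one substitution in each direction, both beyond the scatter. Nothing measured here explains why the number falls with this group.

From the compounds shown here alone, whether a dimethylamino group, a morpholine ring or a plain methoxy group at this same carbon would move the number in the same direction remains open, so the result cannot yet be tied to pyrrolidin-1-yl rather than to substitution here in general. Also open, going by these compounds, are whether pyrrolidin-1-yl would give a step of similar size on the core of compound 1, which has no methoxy group, and what it would do at the other aromatic carbons of that ring.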